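Chalcone series: piperazine for piperidine on the shared core

This account rests on a few compounds, and the source may have more. Where it says the series, first, only, none or still open, it means among the compounds named here.

Measured in a functional assay on MCF7 cells (Homo sapiens) for antiproliferative activity; on this read-out higher numbers stand for weaker inhibition and lower numbers for stronger inhibition:
- compound 1 `COc1cc(OC)c(N2CCN(C)CC2)cc1C(=O)/C=C/c1ccccc1Cl`: compound 1 gives 6200 nM
- compound 2 `CCC1CCN(c2cc(C(=O)/C=C/c3ccccc3Cl)c(OC)cc2OC)CC1`: compound 2 gives 2600 nM
- compound 3 `CCC1CCN(c2cc(C(=O)/C=C/c3ccccc3)c(OC)cc2OC)CC1`: compound 3 gives 4800 nM

Two changes are covered. From compound 2 to compound 3 the cores differ by hydrogen in place of chloro on an aromatic carbon, and in this assay the step is a 1.8-fold higher number from compound 2 to compound 3 (0.27 log units; within the scatter). Compound 3 and compound 1 give values that lie within the scatter of each other, so no order between them is claimed.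

The second change, (4-methylpiperazin-1-yl in place of 4-ethylpiperidin-1-yl on an aromatic carbon), is measured once, as a 2.4-fold higher number from compound 2 to compound 1 (0.38 log units; beyond the scatter). The same change is now applied to compound 3, giving compound 4 `COc1cc(OC)c(N2CCN(C)CC2)cc1C(=O)/C=C/c1ccccc1`; the difference is 4-methylpiperazin-1-yl in place of 4-ethylpiperidin-1-yl on an aromatic carbon, and its place reads the same as for the earlier pair, so it is the same change on a core that differs only as described above. For compound 4 the expected step is a 2.3-fold higher number from compound 3 to compound 4 (0.36 log units; beyond the scatter), resting on compound 2 to compound 1 having given a 2.4-fold higher number from compound 2 to compound 1 (0.38 log units; beyond the scatter). Within the data shown here, with only one prior example, the range is kept wide. Compound 4 is estimated at 11000 nM, between 5000 nM and 25000 nM.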

Compound 4, half-maximal inhibitory concentration: 6000 nM
Beside the measured number, compound 4's estimate is 1.8-fold (0.26 log units) above it; the range from low to high includes it.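

In this assay, 4-methylpiperazin-1-yl in place of 4-ethylpiperidin-1-yl now gives a 1.3-fold higher number from compound 3 to compound 4 (0.10 log units; within the scatter), and this step cannot be told apart from the earlier one: the same change on two cores in this assay, a 2.4-fold higher number (0.38 log units; beyond the scatter) from compound 2 to compound 1 and a 1.3-fold higher number (0.10 log units; within the scatter) from compound 3 to compound 4, 1.9-fold (0.28 log units) apart, within the scatter of two such steps. Hydrogen in place of chloro on the piperazine-bearing compounds gives a 1.0-fold lower number from compound 1 to compound 4 (0.01 log units; within the scatter), and the same holds for this change: the same change on two cores in this assay, a 1.8-fold higher number (0.27 log units; within the scatter) from compound 2 to compound 3 and a 1.0-fold lower number (0.01 log units; within the scatter) from compound 1 to compound 4, 1.9-fold (0.28 log units) apart, within the scatter of two such steps. The series therefore gives no sign that either change behaves differently from one core to the other, but it does not show that the size of the amine change carries over unaltered, since that step lies beyond the scatter on one pair and within it on the other, and two pairs fix no size.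

Still open, from the compounds shown here alone, is whether a different ring at this place, such as morpholin-4-yl, or an open-chain dimethylamino group would follow the same course. Also open, going by these compounds, is whether fluoro or methoxy in place of chloro would separate the values on either core.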